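Compound 4 at the limit of growth inhibition

The source may report more compounds than this note shows. Statements on the series, on what has been measured and on what is new or still open speak of the compounds shown alone.

Measured so far in a functional assay on PC-3 cells (Homo sapiens) for inhibition; a higher number here means a weaker inhibitor of growth, a lower number a stronger inhibitor of growth:
- compound 1 `O=C(NCc1ccccc1)c1nc(-c2ccccc2)[nH]c1C(=O)O`, with no numeric result ("not determined" (no result reported))
- compound 2 `CN(Cc1ccccc1)C(=O)c1nc(-c2ccccc2)[nH]c1C(=O)O`, a limit (> 200000 nM)
- compound 3 `CCOC(=O)CN(Cc1ccccc1)C(=O)c1nc(-c2ccccc2)[nH]c1C(=O)O`, a limit (> 200000 nM)

Compound 3 has only a limit (> 200000 nM) and no number in this assay as its standing. Compound 4 `O=C(O)c1[nH]c(-c2ccccc2)nc1C(=O)N(Cc1ccccc1)Cc1ccccc1` carries phenyl in place of ethoxycarbonyl on a saturated chain carbon bound to an amide-type nitrogen. For the measured compounds named here, the one measured step at that place (a step that the two limits leave unreadable from compound 2 to compound 3) cannot be sized, and the shared limit (the limit of > 200000 nM in this assay, at which 2 of the 3 values shown sit) gives no direction, so no readable change is expected. The estimated step (a number no higher from compound 3 to compound 4 (the limit leaves the size open)) is correspondingly uncertain. Compound 4 is estimated at 200000 nM within an expected range from 80000 nM to 500000 nM in this assay, most likely reported only as a limit.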

Compound 4, concentration for 50% growth inhibition: 21000 nM
Compound 4: the middle estimate sits 9.5-fold (0.98 log units) above what was measured, and the stated range ends above it.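

In this assay, phenyl on a saturated chain carbon bound to an amide-type nitrogen gives an at least 9.5-fold lower number from compound 3 to compound 4 (0.97 log units; beyond the scatter), and, set against hydrogen at that place, an at least 9.5-fold lower number from compound 2 to compound 4 (0.97 log units; beyond the scatter). For the compounds shown here, the earlier step at this place, from hydrogen to ethoxycarbonyl, cannot be read, so these are the first readable changes here and show that this place can move the read-out. Compound 4 is the only compound shown with a value clear of the shared limit: the limit of > 200000 nM in this assay, at which 2 of the 4 values shown sit.

As far as these compounds go, whether a cyclohexyl ring or a pyridine ring at this place would give a similar step remains open. So does whether the carboxylic acid on the shared core could give way to its ethyl ester.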